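The compounds below may be only part of what the source reports. "The series", "measured", "known", "first", "only" and "open" are said of these compounds alone.

Working notes on the series. Compound 1 `O=c1cc(-c2ccccc2)oc2cc(OCCCCNc3nc4ccc([N+](=O)[O-])cc4s3)cc(O)c12` gives 310 ug/mL in an ADME assay on MDCK cells (Canis lupus familiaris) for cytotoxicity, read by sulforhodamine B assay, with a stated time of 48 h; a higher number here means a weaker inhibitor, a lower number a stronger inhibitor; compound 2 `O=c1cc(-c2ccccc2)oc2cc(OCCCCNc3nc4ccc(I)cc4s3)cc(O)c12` gives 298 ug/mL; compound 3 `O=C(O)c1ccc2nc(NCCCCOc3cc(O)c4c(=O)cc(-c5ccccc5)oc4c3)sc2c1` gives 324 ug/mL. The three numbers sit within the scatter of one another, so compound 3 stands level with both partners. The measured steps are a 1.0-fold lower number from compound 1 to compound 2 (0.02 log units; within the scatter), a 1.0-fold higher number from compound 1 to compound 3 (0.02 log units; within the scatter) and a 1.1-fold higher number from compound 2 to compound 3 (0.04 log units; within the scatter): each exchange on the aromatic carbon left the read-out unmoved beyond the scatter. Compound 4 `O=c1cc(-c2ccccc2)oc2cc(OCCCCNNc3nc4ccccc4s3)cc(O)c12` differs from compound 3 by (1,3-benzothiazol-2-yl)amino in place of 6-carboxy-1,3-benzothiazol-2-yl on an amine nitrogen. No measured step covers this exchange directly, but the three flat steps on the same core give no reason to expect movement. For compound 4 the expected step is a 1.0-fold lower number from compound 3 to compound 4 (0.02 log units; within the scatter), none beyond the scatter. The estimate for compound 4 is therefore 310 ug/mL, with a range of 200 ug/mL to 480 ug/mL.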

Compound 4, half-maximal inhibitory concentration: 316 ug/mL
Compound 4: middle estimate off by 1.0-fold (0.01 log units), on the low side; the range from low to high includes it.
By their numbers in this assay, from the lowest: compounds 2, 1, 4 and 3 (each within the scatter of the next).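

In this assay, (1,3-benzothiazol-2-yl)amino on the amine nitrogen leaves the read-out level with all three earlier compounds (a 1.0-fold lower number from compound 3 to compound 4 (0.01 log units; within the scatter); a 1.1-fold higher number from compound 2 to compound 4 (0.03 log units; within the scatter); a 1.0-fold higher number from compound 1 to compound 4 (0.01 log units; within the scatter)). The flat result therefore now extends beyond exchanges on the aromatic carbon to a change in the group on the amine nitrogen, and compound 4 carries no carboxy, iodo or nitro group. No measurement here addresses why the read-out stays level.

Still open, on these data alone, is whether a longer chain on the amine nitrogen would move the read-out. An amine or a hydroxyl on the aromatic carbon also remains untested among the compounds shown.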